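This account rests on a few compounds, and the source may have more. Where it says the series, first, only, none or still open, it means among the compounds named here.

Measured compounds:
Compound 1 `c1coc(-c2ccccc2NCC2=NCCN2)c1`, in a functional assay for activation of Alpha-1D adrenergic receptor (Homo sapiens) (on this read-out lower numbers stand for an effect already at smaller amounts and higher numbers for an effect only at larger amounts of compound), compound 1 gives 16.2 nM.
Compound 2 `Cc1cc(-c2ccccc2NCC2=NCCN2)on1`, for which this assay reports only a limit, < 100000 nM.
Compound 3 `c1ccc(-c2ccccc2NCC2=NCCN2)nc1`, in this assay compound 3 gives 41.7 nM.

Of the two numbers that this assay gives, compound 3 holds the higher one; its nearest neighbour is compound 1, and the step of a 2.6-fold higher number from compound 1 to compound 3 (0.41 log units; beyond the scatter) is a modest one. The third value is a limit (the limit of < 100000 nM in this assay, at which 1 of the 3 values shown sits), so the steps a step that the limit leaves unreadable from compound 1 to compound 2 and a step that the limit leaves unreadable from compound 2 to compound 3 cannot be sized.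

Compound 4 `Cc1cccnc1-c1ccccc1NCC1=NCCN1` differs from compound 3 in one place: methyl in place of hydrogen on an aromatic carbon. Among the measured compounds shown here, none of the three measured steps changes the same position, so no step bears directly on this one. The only shift measured between two numbers, a 2.6-fold higher number from compound 1 to compound 3 (0.41 log units; beyond the scatter), came from exchanging one ring for another and says little about a methyl added on the ring that stays. The expectation is therefore a step of a 1.4-fold higher number from compound 3 to compound 4 (0.16 log units; within the scatter) that is small, possibly towards a somewhat higher number, but not clearly beyond the scatter. For compound 4 the estimated value in this assay is 60 nM, with a range from 15 nM to 250 nM.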

Compound 4, half-maximal effective concentration: < 100000 nM
Compound 4 gave a limit, no number; the forecaster's own chance of this, stated with the estimate: 5%; the middle value does not contradict the limit.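

In this assay, among the compounds shown here, compound 4 gives only a limit, < 100000 nM, so no step from compound 3 to compound 4 can be read. Limits now recur among the values: the limit of < 100000 nM in this assay, at which 2 of the 4 values shown sit.

The compounds shown leave open how far methyl in place of hydrogen shifts the read-out of compound 3.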